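This account rests on a few compounds, and the source may have more. Where it says the series, first, only, none or still open, it means among the compounds named here.

Notes on the series. Compound 1 `CN(C)CCNC(=O)c1c(O)c2cccnc2n(-c2ccccc2)c1=O` in a functional assay on the whole organism for inhibition, with Rattus norvegicus as the target, read by cytopathic effect and paw edema, at a dose of 100 mg/kg by the oral route (on this read-out lower numbers stand for less inhibition and higher numbers for more inhibition at the one dose given (going by the name of the read-out)), gives 18.4%, the second highest of the three numbers in hand. Compound 2 `COc1cccc(NC(=O)c2c(O)c3cccnc3n(-c3ccccc3)c2=O)c1` gives 20.7%, and the step of a number 2.3 percentage points higher from compound 1 to compound 2 (within the scatter) stays within the scatter. Compound 3 `O=C(Nc1nccs1)c1c(O)c2cccnc2n(-c2ccccc2)c1=O` gives 2.5%, the step of a number 15.9 percentage points lower from compound 1 to compound 3 (beyond the scatter) lying beyond the scatter, as does a number 18.2 percentage points lower from compound 2 to compound 3 (beyond the scatter).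

Compound 4 `COc1ccc(NC(=O)c2c(O)c3cccnc3n(-c3ccccc3)c2=O)cn1` differs from compound 1 in one place: 6-methoxypyridin-3-yl in place of 2-(dimethylamino)ethyl on an amide-type nitrogen. Both measured steps bear on this change, since the 3-methoxyphenyl of compound 2 and the 1,3-thiazol-2-yl of compound 3 are likewise aromatic groups on the amide-type nitrogen. The 3-methoxyphenyl left the number within the scatter; the 1,3-thiazol-2-yl lowered it beyond the scatter by a modest amount. The 6-methoxypyridin-3-yl shares its methoxy with compound 2 and its ring hetero atom with compound 3, so the outcome is expected to fall between those two, weighted toward compound 2. In this assay compound 4 is therefore expected to give 15%, in the range 3% to 27%, a step of a number 3.4 percentage points lower from compound 1 to compound 4 (within the scatter) that is expected to stay within the scatter.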

Compound 4, a percentage reported as inhibition, in the whole organism at one dose (the size of the read-out at that dose, not a potency): -10.2%
Compound 4: middle estimate off by 25.2 percentage points, on the high side; the whole stated range lies above it.
By their numbers in this assay, from the lowest: compound 4; then compound 3; then compounds 1 and 2 (each within the scatter of the next).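

The 6-methoxypyridin-3-yl on the amide-type nitrogen shows that aromatic groups at this position do not all read alike in this assay: compound 4 gives -10.2% and stands lowest of the four, with a number 28.6 percentage points lower from compound 1 to compound 4 (beyond the scatter) and a number 30.9 percentage points lower from compound 2 to compound 4 (beyond the scatter). Even the 1,3-thiazol-2-yl, the lowest group until now, gives way, with a number 12.7 percentage points lower from compound 3 to compound 4 (beyond the scatter) and a methoxy shared with compound 2 does not keep the number near that of compound 2. Nothing in hand accounts for the drop.

The compounds shown leave open whether a plain pyridin-3-yl or a 4-methoxyphenyl on this nitrogen would read nearer compound 2 or compound 4. They also leave open how a longer chain such as 3-(dimethylamino)propyl would compare with compound 1.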